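Changing the Aryl Ketone Group from Compound 2 to Compound 3

The compounds below may be only part of what the source reports. "The series", "measured", "known", "first", "only" and "open" are said of these compounds alone.

Of the compounds shown here, two that share one core have been measured so far. In a functional assay on A549 cells (Homo sapiens) for cytotoxicity, read by MTT assay, with a stated time of 48 h (a higher number here means a weaker inhibitor, a lower number a stronger inhibitor), compound 1 `COc1cc(-c2nnc3n2NC(c2cccs2)C(C(=O)c2ccc(Cl)cc2)S3)cc(OC)c1OC` gives 20100 nM. Compound 2 `COc1cc(-c2nnc3n2NC(c2ccco2)C(C(=O)c2ccccc2C)S3)cc(OC)c1OC` gives 80000 nM in this assay, the higher of the two numbers. Compound 1 and compound 2 differ in more than one place, so only their two values can be set side by side. Compound 3 `COc1cc(-c2nnc3n2NC(c2ccco2)C(C(=O)c2ccc([N+](=O)[O-])cc2)S3)cc(OC)c1OC` has not yet been measured. It differs from compound 2 in one place: 4-nitrophenyl in place of 2-methylphenyl on a carbonyl carbon. Among the compounds with values here, with no measured step of this kind to lean on, the step of a 2.0-fold lower number from compound 2 to compound 3 (0.30 log units; within the scatter) is expected to be small, toward a lower number or none beyond the scatter. Compound 3 is therefore estimated at 40000 nM, with a range from 10000 nM to 120000 nM.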

Compound 3, half-maximal inhibitory concentration: > 100000 nM
Compound 3 gave a limit, no number; the forecaster's own chance of this, stated with the estimate: 20%; middle value at least 2.5-fold (0.39 log units) from the limit.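

Swapping 2-methylphenyl for 4-nitrophenyl on this carbonyl carbon gives the first single-place step in the series, an at least 1.2-fold higher number from compound 2 to compound 3 (0.09 log units; that floor lies within the scatter) in this assay. No lower number appears, so this change brings no measurable gain in cytotoxicity. For compound 3, the reading is a limit of the assay, not a number: the limit of > 100000 nM in this assay, at which 1 of the 3 values shown sits.

On these data alone, the true size of the step therefore stays unknown. As far as these compounds go, it also remains open how a phenyl ring carrying an amine or a carboxylic acid at this position would behave in this assay.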